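The compounds below may be only part of what the source reports. "The series", "measured", "known", "first", "only" and "open" are said of these compounds alone.

Measured in a functional assay on the whole organism with Mus musculus as the target; a higher number here means that more compound is needed for the effect, a lower number that less compound is needed:
compound 1 `CC(C)NC(=O)/C=C1\CCc2ccc(F)cc21` gives 96 mg/kg
compound 2 `O=C(/C=C1\CCc2c1ccc(F)c2F)NC1CC1` gives 62 mg/kg
compound 3 `CC(C)NC(=O)/C=C1\CCc2c(F)cc(F)cc21` gives 50 mg/kg

All three values lie within the usual scatter of one another. Compound 3 and compound 1 differ by one change, (hydrogen in place of fluoro on an aromatic carbon), and the step is a 1.9-fold higher number from compound 3 to compound 1 (0.28 log units; within the scatter). Compound 4 `O=C(/C=C1\CCc2cc(F)ccc21)NC1CC1` is reached from compound 2 by hydrogen in place of fluoro on an aromatic carbon. This is the same kind of change: in compound 4 the position is ortho to a fluoro group, in compound 1 it is meta to a fluoro group. The difference between the cores of compound 2 and compound 3 is not broken down here.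

For compound 4 a step of a 1.5-fold higher number from compound 2 to compound 4 (0.19 log units; within the scatter) in this assay is expected, resting on compound 3 and the step of a 1.9-fold higher number from compound 3 to compound 1 (0.28 log units; within the scatter). The estimate for compound 4 is 95 mg/kg, expected between 50 mg/kg and 180 mg/kg.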

Compound 4, dose for half-maximal effect: 81 mg/kg
Beside the measured number, compound 4's estimate is 1.2-fold (0.07 log units) above it; the range from low to high includes it.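

In this assay, hydrogen in place of fluoro on an aromatic carbon gives a 1.3-fold higher number from compound 2 to compound 4 (0.12 log units; within the scatter). Set beside the earlier step, the change reads the same on the two cores: the same change on two cores in this assay, a 1.9-fold higher number (0.28 log units; within the scatter) from compound 3 to compound 1 and a 1.3-fold higher number (0.12 log units; within the scatter) from compound 2 to compound 4, 1.5-fold (0.17 log units) apart, within the scatter of two such steps This agreement rests on only two pairs, each with a step within the scatter, and the change sits at a different position on each core, so it shows neither a real effect of the fluoro group nor a rule that would hold on further cores.

The compounds shown leave open what a chloro or methoxy group would give at the same aromatic carbon. Also open, from the compounds shown here alone, is how an amine or a longer chain on the amide nitrogen would read in this assay.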